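Replacing Nitro with Benzyloxy on a Thiophene-Linked Scaffold

This account rests on a few compounds, and the source may have more. Where it says the series, first, only, none or still open, it means among the compounds named here.

Compound 1 `COc1ccc(-c2cc(C(=O)O)sc2-c2cc(OC)c(OC)c(OC)c2)cc1[N+](=O)[O-]` carries a nitro group and a carboxy group. In a functional assay on SGC-7901 cells (Homo sapiens) for antiproliferative activity, read by MTT assay, with a stated time of 72 h (a higher number here means a weaker inhibitor, a lower number a stronger inhibitor), compound 1 gives 21600 nM. Compound 2 `COc1ccc(-c2cc(C(=O)O)sc2-c2cc(OC)c(OC)c(OC)c2)cc1OCc1ccccc1` keeps the carboxy group but carries a benzyloxy group where compound 1 has the nitro group. For compound 2 this assay reports only a limit, > 100000 nM. The step is an at least 4.6-fold higher number from compound 1 to compound 2 (0.66 log units; beyond the scatter), which is bounded by the limit of > 100000 nM in this assay, at which 1 of the 3 values shown sits. The change behind it is benzyloxy in place of nitro on an aromatic carbon.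

Compound 3 `COc1ccc(-c2ccsc2-c2cc(OC)c(OC)c(OC)c2)cc1[N+](=O)[O-]` differs from compound 1 in the core. In this assay compound 3 gives 10300 nM, so the step is a 2.1-fold lower number from compound 1 to compound 3 (0.32 log units; beyond the scatter). The difference between the two cores is hydrogen in place of carboxy on an aromatic carbon.

Compound 4 `COc1ccc(-c2ccsc2-c2cc(OC)c(OC)c(OC)c2)cc1OCc1ccccc1` has not yet been tested. It stands to compound 3 as compound 2 stands to compound 1: the change is benzyloxy in place of nitro on an aromatic carbon, and the surroundings of the place are described in the same words for both pairs, so this is the same change made on the core of compound 3.

Within the data shown here, the only guide is the earlier pair, and the weakening seen there is expected to carry over: the step is estimated as a 4.9-fold higher number from compound 3 to compound 4 (0.69 log units; beyond the scatter). This rests on compound 1 and compound 2, whose measured step is an at least 4.6-fold higher number from compound 1 to compound 2 (0.66 log units; beyond the scatter). Compound 4 is therefore expected to give 50000 nM in this assay. Its estimate is expected to lie between 20000 nM and 150000 nM.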

Compound 4, half-maximal inhibitory concentration: > 100000 nM
Compound 4: only a limit was reported (the forecaster's own chance of this, stated with the estimate: 30%); middle value at least 2.0-fold (0.30 log units) from the limit.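

Benzyloxy in place of nitro again raises the number on the core without the carboxy group in this assay, with an at least 9.7-fold higher number from compound 3 to compound 4 (0.98 log units; beyond the scatter), so the direction of the change seen on the core with the carboxy group carries over to this second core. What this pair does not show is whether the change costs the same amount on both cores, and the two steps cannot be ranked by size: the same change on two cores in this assay, an at least 4.6-fold higher number (0.66 log units; beyond the scatter) from compound 1 to compound 2 and an at least 9.7-fold higher number (0.98 log units; beyond the scatter) from compound 3 to compound 4; the limit leaves it open whether they differ The step between the two benzyloxy compounds, which would show what removing the carboxy group does in their case, cannot be read, since neither end of it is a number: the limit of > 100000 nM in this assay, at which 2 of the 4 values shown sit.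

The compounds shown leave open the actual numbers of compound 2 and compound 4, and so whether the carboxy group makes any difference once benzyloxy is present. They also leave open what other groups would do at this place, on the aromatic carbon ortho to a methoxy group, such as an amine or a hydroxy group in place of the nitro group, and whether an amide in place of the carboxy group would behave like the carboxy group or like hydrogen.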